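The source may hold more compounds than are shown below. What is called first, only, known or untested is meant among the compounds shown, and "the series" means these compounds.

Measured compounds in a functional assay on SW-620 cells (Homo sapiens) for antiproliferative activity, read by MTT assay, with a stated time of 24 h; a lower number here means a stronger inhibitor, a higher number a weaker inhibitor:
Compound 1 `COc1ccc(C(=O)/C=C/c2ccc(F)cc2)c2c1C=CC(C)(C)O2`: > 10000 nM, a limit of the assay.
Compound 2 `COc1ccc(C(=O)/C=C/c2ccc3ccccc3c2)c2c1C=CC(C)(C)O2`: 2140 nM.
Compound 3 `COc1cc(/C=C/C(=O)c2ccc(OC)c3c2OC(C)(C)C=C3)cc(OC)c1O`: > 10000 nM, a limit of the assay.

Compound 1 stands at the limit of > 10000 nM in this assay, at which 2 of the 3 values shown sit; no number is known for it. Compound 4 `COc1ccc(C(=O)/C=C/c2cc(Cl)ccc2O)c2c1C=CC(C)(C)O2` differs from compound 1 by 5-chloro-2-hydroxyphenyl in place of 4-fluorophenyl on a double-bonded chain carbon bound to a double-bonded chain carbon. Among the measured compounds shown here, no pair of measured compounds differing in one place is available, so the size of this change has no anchor. Compound 2 shows that a value inside the measurable range is reachable on this core. For compound 4 the step of an at least 1.2-fold lower number from compound 1 to compound 4 (0.09 log units; that floor lies within the scatter) is expected to be small, at most a modest shift toward stronger inhibition. Compound 4 is estimated at 8000 nM, within 2500 nM to 30000 nM, with a fair chance that this assay again reports only a limit.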

Compound 4, half-maximal inhibitory concentration: 4230 nM
Beside the measured number, compound 4's estimate is 1.9-fold (0.28 log units) above it; the measured number falls inside the stated range.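

In this assay, this place on a double-bonded chain carbon bound to a double-bonded chain carbon now has its first readable change: 5-chloro-2-hydroxyphenyl in place of 4-fluorophenyl gives an at least 2.3-fold lower number from compound 1 to compound 4 (0.37 log units; beyond the scatter). Compound 4 joins compound 2 in giving a number rather than a limit, so a measurable value on the shared core does not rest on compound 2 alone. The step remains only a floor because compound 1 is held at a limit: the limit of > 10000 nM in this assay, at which 2 of the 4 values shown sit.

The hydroxyl and the chlorine enter together, and their separate shares cannot be read. On these data alone, how a phenyl ring bearing an amine or a carboxylic acid at this place would read also stays open.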